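Working notes on the series: from compound 2 to compound 4

The source may hold more compounds than are shown below. What is called first, only, known or untested is meant among the compounds shown, and "the series" means these compounds.

Measured so far in an ADME assay on HEL cells (Homo sapiens) for cytotoxicity, with a stated time of 3 days; on this read-out higher numbers stand for lower toxicity in this test and lower numbers for higher toxicity in this test:
compound 1 `CC(C)C1(Cc2ccccc2)OS(=O)(=O)C=C1OCc1ccccc1`: >= 80000 nM, a limit of the assay
compound 2 `CCCC1(Cc2ccccc2)OS(=O)(=O)C=C1OCc1ccccc1`: >= 400000 nM, a limit of the assay
compound 3 `C=CCOC1=CS(=O)(=O)OC1(CC)Cc1ccccc1`: 80000 nM

Compound 2 stands only at a limit in this assay, so no number is fixed for it. Among the compounds with values here, the one step between measured compounds, a step that the two limits leave unreadable from compound 1 to compound 2, cannot be sized because the limit of >= 400000 nM in this assay, at which 1 of the 3 values shown sits, and the limit of >= 80000 nM in this assay, at which 1 of the 3 values shown sits, are both limits. Compound 4 `O=S1(=O)C=C(OCc2ccccc2)C(Cc2ccccc2)(Cc2ccccc2)O1` differs from compound 2 by phenyl in place of ethyl on a saturated chain carbon bound to a saturated ring carbon. Within the data shown here, no measured step involves this change, and nothing among the three values argues for a move beyond the scatter, so the step of an at least 5.0-fold lower number from compound 2 to compound 4 (0.69 log units; beyond the scatter) is expected to be small, with compound 4 estimated at 80000 nM within 20000 nM to 400000 nM in this assay.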

Compound 4, minimum cytotoxic concentration: 200000 nM
The estimate for compound 4 lay 2.5-fold (0.40 log units) below the measured number, within the range that was stated.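

In this assay, within the data shown here, phenyl in place of ethyl on a saturated chain carbon bound to a saturated ring carbon gives the first sized step at this position, an at least 2.0-fold lower number from compound 2 to compound 4 (0.30 log units; that floor lies within the scatter). Only a floor is fixed for this step, so propyl to benzyl may amount to no real change or to a larger one. The step from compound 1 to compound 4 cannot be read, as compound 1 stands only at a limit: the limit of >= 80000 nM in this assay, at which 1 of the 4 values shown sits.

Open, on these data alone, is how an amine or a carboxylic acid at this position would read in this assay. As far as these compounds go, a longer chain in place of propyl is equally open.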